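This account rests on a few compounds, and the source may have more. Where it says the series, first, only, none or still open, it means among the compounds named here.

Measured compounds:
Compound 1 `COc1cc2nc(Cl)nc(NS(=O)(=O)c3cccc(C(F)(F)F)c3)c2cc1OC` gives 59.1 ug/mL in a functional assay on U-937 cells (Homo sapiens) for cytotoxicity, read by MTT assay, with a stated time of 24 h; a lower number here means a stronger inhibitor, a higher number a weaker inhibitor.
Compound 2 `COc1cc2nc(N3CCCC3)nc(NS(=O)(=O)c3cccc(C(F)(F)F)c3)c2cc1OC` gives 16 ug/mL.
Compound 3 `COc1ccc(S(=O)(=O)Nc2nc(Cl)nc3cc(OC)c(OC)cc23)cc1C` gives 41.1 ug/mL.

Compound 3 stands second highest of these three numbers. Its nearest neighbour is compound 1, and the two values lie within the scatter of each other, so nothing can be said of their order. Compound 2 sits further away, with a number beyond the scatter below that of compound 3.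

For the measured compounds named here, the one step measured within this set, a 3.7-fold lower number from compound 1 to compound 2 (0.57 log units; beyond the scatter), concerns the exchange of a chloro group for a pyrrolidin-1-yl group and leaves the sulfonyl side untouched. The step from compound 3 to compound 4 `COc1cc2nc(Cl)nc(NS(=O)(=O)Cc3ccccc3)c2cc1OC` works at the other end of the molecule: benzyl in place of 4-methoxy-3-methylphenyl on a sulfonyl sulfur. Going by the values given here, no measured pair shows the effect of changing the group on the sulfonyl sulfur; compounds 1 and 3 carry different groups there but are separated by no recorded step, and their values fall within the scatter of each other. On that basis no step beyond the scatter is expected for compound 4, and its number is estimated to lie near that of compound 3.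

Compound 4 is therefore expected at 45 ug/mL, in a range from 18 ug/mL to 110 ug/mL, which means an expected step of a 1.1-fold higher number from compound 3 to compound 4 (0.04 log units; within the scatter).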

Compound 4, half-maximal inhibitory concentration: 91.7 ug/mL
Compound 4: middle estimate off by 2.0-fold (0.31 log units), on the low side, within the range that was stated.
By their numbers in this assay, from the lowest: compound 2; then compounds 3, 1 and 4 (each within the scatter of the next, the first and the last beyond it).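

In this assay, for the compounds shown here, the exchange of 4-methoxy-3-methylphenyl for benzyl on the sulfonyl sulfur gives a 2.2-fold higher number from compound 3 to compound 4 (0.35 log units; beyond the scatter) and is the first measured step at this position. Going by these compounds alone, it shows that the group on the sulfonyl sulfur can shift the number beyond the scatter, whereas the only earlier step came from replacing chloro with pyrrolidin-1-yl on an aromatic carbon. The shift here is modest and goes towards a weaker inhibitor, but nothing available explains it.

The compounds shown do not separate the loss of the methoxy and methyl groups from the change to benzyl, so an unsubstituted phenyl or a 2-phenylethyl group on the sulfonyl sulfur would be needed to tell these apart. They also leave open whether replacing chloro with pyrrolidin-1-yl, or with another cyclic amine such as morpholine, would lower the number when benzyl is the group on the sulfonyl sulfur.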